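This account rests on a few compounds, and the source may have more. Where it says the series, first, only, none or still open, it means among the compounds named here.

Of the compounds shown here, two built on one shared core have so far been tested in a functional assay on HeLa cells (Homo sapiens) for antiproliferative activity, with a stated time of 24 h; on this read-out lower numbers stand for stronger inhibition and higher numbers for weaker inhibition. Compound 1, with structure `NC(=O)c1c(NC(=O)c2ccccc2Cl)sc2c1CCN(C(=S)Nc1ccc(C(F)(F)F)cc1)C2`, gives no number in this assay but only a limit, > 50000 nM. Among the compounds with values here, compound 2, with structure `NC(=O)c1c(NC(=O)c2ccc(C(F)(F)F)cc2)sc2c1CCN(C(=S)Nc1ccccc1Cl)C2`, gives 44000 nM in this assay; this is the only number measured here, and compound 2 stands as a weak inhibitor. Compound 3, with structure `NC(=O)c1c(NC(=O)c2ccc(C(F)(F)F)cc2)sc2c1CCN(C(=S)Nc1ccc(C(F)(F)F)cc1)C2`, has not yet been measured. It differs from compound 2 in one place: 4-(trifluoromethyl)phenyl in place of 2-chlorophenyl on an amide-type nitrogen, which gives compound 3 the same group on its thiourea nitrogen that compound 1 carries. Within the data shown here, no step between two measured compounds is available, so the size of this change cannot be read from the data. Both measured compounds are weak, and compound 1 shows (the limit of > 50000 nM in this assay, at which 1 of the 2 values shown sits). The expected step is a 1.1-fold higher number from compound 2 to compound 3 (0.06 log units; within the scatter), not beyond the usual scatter. Compound 3 is estimated at 50000 nM, ranging from 20000 nM to 120000 nM.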

Compound 3, half-maximal inhibitory concentration: > 50000 nM
Compound 3 was reported as a limit; the forecaster's own chance of this, stated with the estimate: 55%; the middle value lies on the limit itself.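

In this assay, within the data shown here, 4-(trifluoromethyl)phenyl in place of 2-chlorophenyl on an amide-type nitrogen gives an at least 1.1-fold higher number from compound 2 to compound 3 (0.05 log units; that floor lies within the scatter), so the one number measured so far does not get lower with this change. Going by these compounds, compound 3 gives > 50000 nM, which is a limit and not a number, so only a floor can be stated for this step and its true size stays unknown. The step from compound 1 to compound 3 cannot be read, and most of the set now rests on a single limit: the limit of > 50000 nM in this assay, at which 2 of the 3 values shown sit.

On these data alone, the true numbers behind the limits of compound 1 and compound 3 remain open. As far as these compounds go, it is also open whether a phenyl ring carrying an amine or a carboxylic acid, or a butyl chain, on this nitrogen would give a clearly lower number in this assay.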